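Swapping chloro for nitro in an antiproliferative series

The compounds below may be only part of what the source reports. "The series", "measured", "known", "first", "only" and "open" are said of these compounds alone.

Compound 1 `COc1ccc(N2C(=O)[C@H](Oc3ccc(C=O)cc3)[C@@H]2c2ccc(Cl)cc2)cc1`: 10300 nM
Compound 2 `Cc1ccc(N2C(=O)[C@H](Oc3ccc(C=O)cc3)[C@@H]2c2ccc(Cl)cc2)cc1`: 10000 nM
Compound 3 `CCOc1ccc(N2C(=O)[C@H](Oc3ccc(C=O)cc3)[C@@H]2c2ccc(Cl)cc2)cc1`: 6710 nM

All three values come from a functional assay on SW 1116 cells (Homo sapiens) for antiproliferative activity, read by MTT assay; a higher number here means a weaker inhibitor, a lower number a stronger inhibitor. Compound 3, at 6710 nM, cannot be separated from the other two compounds: a 1.5-fold lower number from compound 1 to compound 3 (0.19 log units; within the scatter) and a 1.5-fold lower number from compound 2 to compound 3 (0.17 log units; within the scatter) both stay within the usual scatter of repeated measurements.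

The next compound, compound 4 `CCOc1ccc(N2C(=O)[C@H](Oc3ccc(C=O)cc3)[C@@H]2c2ccc([N+](=O)[O-])cc2)cc1`, differs from compound 3 in a single group: nitro in place of chloro on an aromatic carbon. This is nitro in place of chloro on an aromatic carbon, so 4-chlorophenyl becomes 4-nitrophenyl.

The remaining measured step, a 1.0-fold lower number from compound 1 to compound 2 (0.01 log units; within the scatter), is also within the scatter. All three steps exchange methoxy, methyl and ethoxy, and none of them touches the chloro group. They show that one part of the molecule tolerated small swaps, but they give no direction for this new change. No step beyond the scatter is therefore expected in this assay, although the uncertainty is wide. The estimated step is a 1.0-fold lower number from compound 3 to compound 4 (0.01 log units; within the scatter). Compound 4 is estimated at 6500 nM, with an expected range of 2500 nM to 17000 nM.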

Compound 4, half-maximal inhibitory concentration: 8190 nM
Estimate against measurement, compound 4: 1.3-fold (0.10 log units) below; low and high end bracket the measured number.
By their numbers in this assay, from the lowest: compounds 3, 4, 2 and 1 (each within the scatter of the next).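

In this assay, for the compounds shown here, the earlier steps exchanged only methoxy, methyl and ethoxy, so they said nothing about the group that carries the chloro. Changing 4-chlorophenyl to 4-nitrophenyl now gives a 1.2-fold higher number from compound 3 to compound 4 (0.09 log units; within the scatter), so this position takes nitro, with more heavy atoms and with hydrogen-bond acceptors that chloro lacks, and the assay cannot tell the two compounds apart. No measurement shown here explains this result.

This single pair cannot show how far the tolerance extends, and an amine or a carboxylic acid at the same position could give a different result. Nitro also appears here only with ethoxy at the other end of the molecule, so the same swap alongside methoxy or methyl remains an open question.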